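Swapping bromo for hydroxy on a weakly active triazole

The compounds below may be only part of what the source reports. "The series", "measured", "known", "first", "only" and "open" are said of these compounds alone.

Compound 1, `COc1ccc(Cn2nncc2-c2cc(OC)c(OC)c(OC)c2)cc1`: in a functional assay on K562 cells (Homo sapiens) for cytotoxicity, read by MTT assay, with a stated time of 5 days (on this read-out higher numbers stand for weaker inhibition and lower numbers for stronger inhibition), compound 1 gives 8660 nM.
Compound 2, `COc1ccc(Cn2cc(-c3cc(OC)c(OC)c(OC)c3)nn2)cc1`: in this assay compound 2 gives > 10000 nM, which is a limit of the assay and not a number.
Compound 3, `COc1ccc(Cn2cc(-c3cc(OC)c(OC)c(OC)c3)nn2)cc1Br`: in this assay compound 3 gives > 10000 nM, again a limit and not a number.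

Compound 3 therefore sits at the limit of > 10000 nM in this assay, at which 2 of the 3 values shown sit. For the measured compounds named here, of the three compounds only compound 1 returns a number, and it differs from compound 3 in more than one place, so no single step connects them. Going by the values given here, the one step that does bear on compound 3 is a step that the two limits leave unreadable from compound 2 to compound 3, whose size cannot be read because both ends are limits.

Compound 4, `COc1ccc(Cn2cc(-c3cc(OC)c(OC)c(OC)c3)nn2)cc1O`, differs from compound 3 by hydroxy in place of bromo on an aromatic carbon. Among the compounds with values here, with the only neighbouring step unreadable, there is no measured guide to how a hydroxy in this place behaves, and the expectation rests on compound 3 alone. The step that the limit leaves unreadable from compound 3 to compound 4 is expected to be small, with a limit the most likely outcome. Compound 4 is therefore estimated at 12000 nM, with a range from 3500 nM to 40000 nM.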

Compound 4, half-maximal inhibitory concentration: > 10000 nM
Compound 4: a limit, no number; the forecaster's own chance of this, stated with the estimate: 60%; the middle value lies beyond the limit too.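

No step can be read among compound 2, compound 3 and compound 4, since each stands at a limit and not at a number: the limit of > 10000 nM in this assay, at which 3 of the 4 values shown sit. The compounds shown leave open how hydrogen, bromo and hydroxy in this place compare in this assay.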